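The source may report more compounds than this note shows. Statements on the series, on what has been measured and on what is new or still open speak of the compounds shown alone.

Compound 1 `O=C(NCc1ccc(S(=O)(=O)c2cccc(C(F)(F)F)c2)cc1)c1cc2cnccc2[nH]1` gives 8 nM in an assay for inhibition of Nicotinamide phosphoribosyltransferase (Homo sapiens), read by mass spectrometry, with stated times of 15 min and 30 min (on this read-out lower numbers stand for stronger inhibition and higher numbers for weaker inhibition), and carries the highest number of the three measured compounds. Compound 2 `O=C(NCc1ccc(S(=O)(=O)c2cccc(C(F)(F)F)c2)cc1)c1cc2ccncc2o1` gives 5 nM and compound 3 `O=C(NCc1ccc(S(=O)(=O)c2cccc(C(F)(F)F)c2)cc1)c1cc2ccncc2s1` gives 3 nM; the steps are a 1.6-fold lower number from compound 1 to compound 2 (0.20 log units; within the scatter), a 1.7-fold lower number from compound 2 to compound 3 (0.22 log units; within the scatter) and a 2.7-fold lower number from compound 1 to compound 3 (0.43 log units; beyond the scatter), all of them replacing the bicyclic amide at the carbonyl carbon while the sulfone side is held fixed. Compound 4 `O=C(NCc1ccc(S(=O)(=O)c2ccc(F)cc2)cc1)c1cc2cnccc2[nH]1` instead changes the sulfone side: 4-fluorophenyl in place of 3-(trifluoromethyl)phenyl on a sulfonyl sulfur. Going by the values given here, none of the measured steps touches this position, so they give no guide to its size or direction. For compound 4 a number near that of compound 1 is expected, with a wide range, as a 2.5-fold higher number from compound 1 to compound 4 (0.40 log units; beyond the scatter), giving an estimate of 20 nM between 5 nM and 80 nM.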

Compound 4, half-maximal inhibitory concentration: 17 nM
For compound 4 the middle estimate is 1.2-fold (0.07 log units) above the measured one; the measured number falls inside the stated range.
By their numbers in this assay, from the lowest: compounds 3, 2 and 1 (each within the scatter of the next, the first and the last beyond it); then compound 4.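

In this assay the sulfone side proves to be a position that responds: 4-fluorophenyl in place of 3-(trifluoromethyl)phenyl on a sulfonyl sulfur gives a 2.1-fold higher number from compound 1 to compound 4 (0.33 log units; beyond the scatter) and so moves the number modestly, with the core of compound 1 held fixed. Nothing available explains this step.

Which part of the swap carries the step stays open, since the substituent and its place on the phenyl change together. Also open, on these data alone, are how an amine or a carboxylic acid on that phenyl would read, and whether the step holds with the bicyclic amides of compound 2 and compound 3.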